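Chloro for Nitro on an N-Hydroxy Enaminone Series

This account rests on a few compounds, and the source may have more. Where it says the series, first, only, none or still open, it means among the compounds named here.

Measured compounds:
Compound 1, `CN(O)/C=C\C(=O)c1ccc2ccccc2c1`, 1800 nM.
Compound 2, `CN(O)/C=C\C(=O)c1ccc([N+](=O)[O-])cc1`, 1500 nM.
Compound 3, `CCc1c(N(O)/C=C\C(=O)c2ccc3ccccc3c2)ccc2ccccc12`, 750 nM.

Of the compounds shown here, three have been tested in an assay on RBL-1 cells for inhibition of Polyunsaturated fatty acid 5-lipoxygenase (Rattus norvegicus); a lower number here means a stronger inhibitor, a higher number a weaker inhibitor. Compound 1 gives 1800 nM, compound 2 gives 1500 nM and compound 3 gives 750 nM. Compound 2 holds the second highest of the three numbers; its nearest neighbour is compound 1, which lies within the scatter of it, and compound 3, the furthest, is also within the scatter. Among the compounds with values here, no pairwise step between these compounds has been worked out, so the three values can only be read as a cluster of similar results.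

The next compound, compound 4, is `CN(O)/C=C\C(=O)c1ccc(Cl)cc1`. It differs from compound 2 in one place: chloro in place of nitro on an aromatic carbon. The three values seen so far give no guide to what this exchange does in this assay. Compound 4 is therefore expected to land close to compound 2, with no step beyond the scatter, namely no change at the digits printed from compound 2 to compound 4 (within the scatter). The estimate for compound 4 is 1500 nM, with a range from 500 nM to 5000 nM.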

Compound 4, half-maximal inhibitory concentration: 550 nM
Estimate against measurement, compound 4: 2.7-fold (0.44 log units) above; low and high end bracket the measured number.
By their numbers in this assay, from the lowest: compounds 4, 3, 2 and 1 (each within the scatter of the next, the first and the last beyond it).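

In this assay, within the data shown here, chloro in place of nitro on an aromatic carbon, para to a group of 7 heavy atoms, gives the first step that can be read: a 2.7-fold lower number from compound 2 to compound 4 (0.44 log units; beyond the scatter). Among these compounds, the values of the earlier compounds could only be read as a cluster, whereas this pair shows that the number responds to a change at this position, although the step is modest. Chloro brings one heavy atom and no hydrogen-bond acceptors where nitro had three heavy atoms and two acceptors, but nothing shown ties the step to either difference.

A single pair leaves open how the number would move with a fluoro, a methoxy or an amine at this carbon. It also leaves open whether chloro in place of nitro would give a similar step on another core.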